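Methoxy for bromo on the benzylamine of compound 3

A few compounds are considered here, and "the series" means these few. Any claim that something is new, unique, unknown or untested is made for them only; others in the source may bear on it.

Compound 1 `COc1ccc(CNCCCNS(=O)(=O)c2cc(C(F)(F)F)cc(C(F)(F)F)c2)cc1OC`: 15000 nM
Compound 2 `O=S(=O)(NCCCNCC1COc2ccccc2O1)c1cc(C(F)(F)F)cc(C(F)(F)F)c1`: 2500 nM
Compound 3 `O=S(=O)(NCCCNCc1ccc(Br)cc1)c1cc(C(F)(F)F)cc(C(F)(F)F)c1`: 2000 nM

In a functional assay on Capan-2 cells (Homo sapiens) for inhibition, read by MTT assay, with a stated time of 72 h (on this read-out higher numbers stand for weaker inhibition of growth and lower numbers for stronger inhibition of growth), compound 3 gives the lowest number of the three; the gap to compound 2 is within the scatter, while the step of a 7.5-fold lower number from compound 1 to compound 3 (0.88 log units; beyond the scatter) is beyond it. Compound 4 `COc1ccc(CNCCCNS(=O)(=O)c2cc(C(F)(F)F)cc(C(F)(F)F)c2)cc1` differs from compound 3 by methoxy in place of bromo on an aromatic carbon. Among the measured compounds shown here, no measured step covers this exact exchange. Compound 1, carrying a 3,4-dimethoxyphenyl group, shows a 7.5-fold lower number from compound 1 to compound 3 (0.88 log units; beyond the scatter) against compound 3, and compound 4 sits between those two structures. A higher number than compound 3 is therefore expected for compound 4, of modest size: a 2.5-fold higher number from compound 3 to compound 4 (0.40 log units; beyond the scatter). Compound 4 is estimated at 5000 nM, with a range from 1500 nM to 20000 nM.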

Compound 4, concentration for 50% growth inhibition: 2400 nM
The estimate for compound 4 lay 2.1-fold (0.32 log units) above the measured number; the measured number falls inside the stated range.
By their numbers in this assay, from the lowest: compounds 3, 4 and 2 (each within the scatter of the next); then compound 1.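

In this assay, the bromo and methoxy groups cannot be told apart at this position: a 1.2-fold higher number from compound 3 to compound 4 (0.08 log units; within the scatter), and a 1.0-fold lower number from compound 2 to compound 4 (0.02 log units; within the scatter). Among the compounds shown here, what sets compound 1 apart is its extra methoxy, as replacing it with hydrogen gives a 6.3-fold lower number from compound 1 to compound 4 (0.80 log units; beyond the scatter), the only new step beyond the scatter. Nothing available here accounts for either result.

The compounds shown leave open whether a hydroxy, a fluoro or a dimethylamino group on this same aromatic carbon would stay within the scatter of compound 3 and compound 4.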